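From hydroxy to ethoxy in a small ester series

This account rests on a few compounds, and the source may have more. Where it says the series, first, only, none or still open, it means among the compounds named here.

Compound 1 `CCOC(=O)c1cnc(-c2ccccc2F)[nH]c1=O` gives > 10 mg/kg
Compound 2 `CCOC(=O)c1cnc(-c2ccccc2[N+](=O)[O-])[nH]c1=O` gives "not determined" (no result reported)
Compound 3 `CCOC(=O)c1cnc(-c2ccccc2O)[nH]c1=O` gives 5 mg/kg

For the measured compounds named here, in a functional assay on the whole organism (strain Sprague-Dawley) for inhibition, with Rattus norvegicus as the target, with a stated time of 10 min (a lower number here means that less compound is needed, a higher number that more compound is needed for the effect), compound 3 gives 5 mg/kg as the only actual number in the set. The entry for compound 1 is a limit and not a number. Compound 2 offers no result for comparison.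

Compound 4 `CCOC(=O)c1cnc(-c2ccccc2OCC)[nH]c1=O` comes from compound 3 by ethyl in place of hydrogen on an oxygen on an aromatic ring with ethyl in place of hydrogen on an oxygen on an aromatic ring, that is, hydroxy to ethoxy.

Going by the values given here, only one measured step bears on this change: an at least 2.0-fold lower number from compound 1 to compound 3 (0.30 log units; that floor lies within the scatter) with hydroxy in place of fluoro on an aromatic carbon. On these data alone, compound 1 marks the limit of > 10 mg/kg in this assay, at which 1 of the 3 values shown sits, as the start of that step, so its true size stays open. Compound 4 keeps an oxygen on the aromatic ring, as compound 3 with 5 mg/kg does, so a large loss is not expected. The expected move is a 2.0-fold lower number from compound 3 to compound 4 (0.30 log units; within the scatter) and no more than modest. For compound 4 the estimate is 2.5 mg/kg with an expected range from 0.4 mg/kg to 10 mg/kg in this assay.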

Compound 4, dose for 50% inhibition: 2 mg/kg
Compound 4: middle estimate off by 1.3-fold (0.10 log units), on the high side, and the stated range covers the measured number.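

Ethyl in place of hydrogen on an oxygen on an aromatic ring does not lose the effect, so a free hydroxy is not required at this place in this assay: a 2.5-fold lower number from compound 3 to compound 4 (0.40 log units; beyond the scatter). For the compounds shown here, the ethoxy group also gives the first comparison with fluoro that clears the scatter, which the step from fluoro to hydroxy did not do: an at least 5.0-fold lower number from compound 1 to compound 4 (0.69 log units; beyond the scatter). Compound 1 is a limit and not a number, so the true size of that comparison stays open: the limit of > 10 mg/kg in this assay, at which 1 of the 4 values shown sits.

With ethyl as the only group shown on this oxygen, the compounds leave open whether methoxy or a longer chain would give a lower or a higher number. They also leave open whether an amine could take the place of the oxygen, and they give no cause for the step.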